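From ethoxy to morpholin-4-yl on a growth inhibitor

The source may hold more compounds than are shown below. What is called first, only, known or untested is meant among the compounds shown, and "the series" means these compounds.

In a functional assay on A549 cells (Homo sapiens) for inhibition, read by sulforhodamine B assay, with a stated time of 72 h (on this read-out lower numbers stand for stronger inhibition of growth and higher numbers for weaker inhibition of growth), compound 1 `NNC(=O)CCc1ccncc1-c1ccc2ccccc2c1` gives > 10000 nM, which is a limit of the assay and not a number. Within the data shown here, compound 2 `CCOC(=O)/C=C/c1ccncc1-c1ccc2ccccc2c1` gives 5380 nM, the only true number so far. Compound 3 `O=C(/C=C/c1ccncc1-c1ccc2ccccc2c1)N1CCOCC1` carries morpholin-4-yl in place of ethoxy on a carbonyl carbon. Among the measured compounds shown here, the one measured step, an at least 1.8-fold lower number from compound 1 to compound 2 (0.26 log units; that floor lies within the scatter), changes a different group and only its floor is known, so it offers little guidance. No change beyond the scatter is expected, and the estimated step is a 1.3-fold higher number from compound 2 to compound 3 (0.11 log units; within the scatter). Compound 3 is expected at 7000 nM, with an estimated range of 2500 nM to 18000 nM.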

Compound 3, concentration for 50% growth inhibition: 8410 nM
For compound 3 the middle estimate is 1.2-fold (0.08 log units) below the measured one; measured number inside the range.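

Morpholin-4-yl in place of ethoxy on a carbonyl carbon gives a 1.6-fold higher number from compound 2 to compound 3 (0.19 log units; within the scatter) in this assay, so this larger group, which brings a ring, leaves no change that can be told from scatter. Unlike the earlier step, this one has true numbers at both ends. Compound 1 stands at a limit of the assay, not a number: the limit of > 10000 nM in this assay, at which 1 of the 3 values shown sits.

Going by these compounds, whether a carboxylic acid or a small amine on this carbonyl carbon would move the number beyond the scatter stays open.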